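A few compounds are considered here, and "the series" means these few. Any claim that something is new, unique, unknown or untested is made for them only; others in the source may bear on it.

Measured compounds:
Compound 1 `Oc1ccccc1-c1cc(-c2ccco2)cc(-c2ccccc2O)n1`: in a functional assay on DU-145 cells (Homo sapiens) for cytotoxicity, read by CCK-8 assay (a higher number here means a weaker inhibitor, a lower number a stronger inhibitor), compound 1 gives > 50000 nM, which is a limit of the assay and not a number.
Compound 2 `Oc1ccc(-c2cc(-c3ccco3)cc(-c3ccccc3O)n2)cc1`: in this assay compound 2 gives > 50000 nM, also a limit.
Compound 3 `Oc1ccc(-c2cc(-c3ccco3)cc(-c3ccc(O)cc3)n2)cc1`: in this assay compound 3 gives > 50000 nM, also a limit.

Compound 2 thus stands at the limit, as does every value shown here (the limit of > 50000 nM in this assay, at which 3 of the 3 values shown sit). Compound 4 `Oc1ccc(-c2cc(-c3ccoc3)cc(-c3ccccc3O)n2)cc1` differs from compound 2 in one place: furan-3-yl in place of furan-2-yl on an aromatic carbon. For the measured compounds named here, the only measured steps, a step that the two limits leave unreadable from compound 1 to compound 2 and a step that the two limits leave unreadable from compound 2 to compound 3, change a different group, and their size cannot be read: both ends sit at the limit. Going by the values given here, no measured step touches the furan ring, so no direction is expected for a number no higher from compound 2 to compound 4 (the limit leaves the size open), and a limit is again the likely outcome. Compound 4 is expected to give 50000 nM, with a range from 25000 nM to 100000 nM.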

Compound 4, half-maximal inhibitory concentration: 28000 nM
Beside the measured number, compound 4's estimate is 1.8-fold (0.25 log units) above it; measured number inside the range.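

In this assay, furan-3-yl in place of furan-2-yl on the carbon opposite the ring nitrogen gives an at least 1.7-fold lower number from compound 2 to compound 4 (0.25 log units; that floor lies within the scatter). For the compounds shown here, the earlier steps between hydroxyphenyl groups cannot be read, whereas this swap of one furan attachment for another, with the same atoms, gives a step with a readable floor, though its true size stays open. Compound 4 is the only compound shown with a number rather than a limit: the limit of > 50000 nM in this assay, at which 3 of the 4 values shown sit.

As far as these compounds go, it remains open whether furan-3-yl would have the same effect with the hydroxyphenyl groups of compound 1 or compound 3. From the compounds shown here alone, how an amine or a carboxylic acid at this position would read is also open.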